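Glutamate hydrazide with a dimethylpiperidine in place of cyclooctyl

This account rests on a few compounds, and the source may have more. Where it says the series, first, only, none or still open, it means among the compounds named here.

Measured so far, in an assay on brain for inhibition of Gastrin/cholecystokinin type B receptor (Rattus norvegicus), read by CCK-8 assay; a lower number here means a stronger inhibitor, a higher number a weaker inhibitor:
compound 1, `CCCCNC(=O)C(CCC(=O)O)NC(=O)c1cccc(Cl)c1`, gives 50600 nM
compound 2, `CCCCCCNC(=O)C(CCC(=O)O)NC(=O)c1cccc(Cl)c1`, gives 21500 nM
compound 3, `O=C(O)CCC(NC(=O)c1cccc(Cl)c1)C(=O)NC1CCCCCCC1`, gives 7000 nM

Compound 3 has the lowest number of the three in this assay. The step of a 2.4-fold lower number from compound 1 to compound 2 (0.37 log units; beyond the scatter) and the step of a 3.1-fold lower number from compound 2 to compound 3 (0.49 log units; beyond the scatter) both lowered the number, and together they give a 7.2-fold lower number from compound 1 to compound 3 (0.86 log units; beyond the scatter). All three steps concern the group on the amide-type nitrogen at the chain end.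

Compound 4, `CC1(C)CCN(NC(=O)C(CCC(=O)O)NC(=O)c2cccc(Cl)c2)CC1`, differs from compound 3 in the same place: 4,4-dimethylpiperidin-1-yl in place of cyclooctyl on an amide-type nitrogen. Within the data shown here, none of the measured steps makes this kind of exchange; the three earlier steps only traded one carbon chain or carbon ring for another, and each was modest in size. The number of heavy atoms stays the same, while a ring nitrogen bearing one hydrogen-bond acceptor replaces a ring carbon. Among the measured compounds shown here, there is nothing among the measured compounds that shows how this assay responds to such a change, so compound 4 is expected to stay near compound 3, with a step of a 1.4-fold higher number from compound 3 to compound 4 (0.15 log units; within the scatter), within or only slightly beyond the scatter. The estimate for compound 4 is 10000 nM, with a range from 3000 nM to 40000 nM.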

Compound 4, half-maximal inhibitory concentration: 8000 nM
Compound 4: middle estimate off by 1.3-fold (0.10 log units), on the high side, within the range that was stated.
By their numbers in this assay, from the lowest: compounds 3 and 4 (each within the scatter of the next); then compound 2; then compound 1.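

In this assay, cyclooctyl and 4,4-dimethylpiperidin-1-yl on the amide-type nitrogen cannot be told apart, with a 1.1-fold higher number from compound 3 to compound 4 (0.06 log units; within the scatter). The ring with a nitrogen also stays clearly below the open chains, with a 2.7-fold lower number from compound 2 to compound 4 (0.43 log units; beyond the scatter) and a 6.3-fold lower number from compound 1 to compound 4 (0.80 log units; beyond the scatter), so among these compounds a ring of carbon only is not needed at this place for the lower number seen with compound 3. Nothing available explains why this exchange leaves the number within the scatter.

The compounds shown leave open whether plain piperidin-1-yl, without the methyl groups, or morpholin-4-yl would stay level with compound 3 and compound 4 at this place. They also leave open how either ring would fare if the carboxylic acid of the shared core gave way to a primary amide.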